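Cytotoxicity series: aryl amide hexanoic acids and esters

The source may report more compounds than this note shows. Statements on the series, on what has been measured and on what is new or still open speak of the compounds shown alone.

Measured compounds:
compound 1, `CC(C)N(Cc1cccc(OCCCCCC(=O)O)c1)C(=O)c1ccc(-c2cccc(C(F)(F)F)c2)cc1`, > 26000 nM
compound 2, `CC(C)N(Cc1cccc(OCCCCCC(=O)O)c1)C(=O)c1ccc(-c2cccc(Br)c2)cc1`, > 26000 nM
compound 3, `CCOC(=O)CCCCCOc1cccc(CN(C(=O)c2ccc(-c3cccc(C(F)(F)F)c3)cc2)C(C)C)c1`, > 26000 nM

The series is read in an ADME assay on HEK293 cells (Homo sapiens) for cytotoxicity, read by CellTiter-Glo and resazurin assay, with a stated time of 72 h; on this read-out lower numbers stand for an effect already at smaller amounts and higher numbers for an effect only at larger amounts of compound. In this assay compound 1 gives only a limit, > 26000 nM. Compound 2 likewise gives only a limit, > 26000 nM. Compound 3 also gives only a limit, > 26000 nM. All three values sit at the same limit, (the limit of > 26000 nM in this assay, at which 3 of the 3 values shown sit).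

Compound 1 and compound 2 differ by bromo in place of trifluoromethyl on an aromatic carbon. The step that the two limits leave unreadable from compound 1 to compound 2 cannot be sized, since both ends are limits. Compound 1 and compound 3 differ in the core by ethyl in place of hydrogen on an oxygen next to a carbonyl group, and the step that the two limits leave unreadable from compound 1 to compound 3 is likewise not readable for the same reason.

Compound 4, `CCOC(=O)CCCCCOc1cccc(CN(C(=O)c2ccc(-c3cccc(Br)c3)cc2)C(C)C)c1`, is not yet measured. Compound 4 differs from compound 3 by bromo in place of trifluoromethyl on an aromatic carbon. This is the same kind of change as that from compound 1 to compound 2, set on the core of compound 3 instead of the core of compound 1; the surroundings of the place are described in the same words for both pairs. Because compound 1, compound 2 and compound 3 all sit at the limit (the limit of > 26000 nM in this assay, at which 3 of the 3 values shown sit), no direction or size can be drawn from the measured step, and compound 4 is expected to behave like its neighbours. The step from compound 3 to compound 4 is expected to be a number no higher from compound 3 to compound 4 (the limit leaves the size open), meaning essentially no readable change. Compound 4 is estimated at 26000 nM, within 13000 nM to 100000 nM, most probably reported as a limit again.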

Compound 4, half-maximal effective concentration: > 26000 nM
Compound 4: no number, only a limit (the forecaster's own chance of this, stated with the estimate: 85%); the middle value lies on the limit itself.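

In this assay compound 4 gives > 26000 nM as a limit. No new step can be read from compound 3 to compound 4 or from compound 2 to compound 4, since both ends of each pair are limits: the limit of > 26000 nM in this assay, at which 4 of the 4 values shown sit. The compounds shown leave open at what concentration any of them would reach a half-maximal effect, and whether either change alters that concentration.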